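Changing the Anilino Group: From Compound 3 to Compound 4

The source may hold more compounds than are shown below. What is called first, only, known or untested is meant among the compounds shown, and "the series" means these compounds.

Compound 1 `COc1cc(NC(=O)Nc2cc(Nc3cc(Br)ccc3OC)ncn2)cc(OC)c1` gives 43.5% in a functional assay on NCI-H520 cells (Homo sapiens) for inhibition, read by MTT assay, with a stated time of 48 h, tested at 10 uM; a lower number here means less inhibition, a higher number more inhibition at the concentration tested (going by the name of the read-out). Compound 2 `CCc1cccc(Nc2cc(NC(=O)Nc3cc(OC)cc(OC)c3)ncn2)c1` gives 23%. Compound 3 `COc1cc(NC(=O)Nc2cc(Nc3ccc(F)c(Cl)c3)ncn2)cc(OC)c1` gives 25.5%.

Compound 3 stands second highest of the three. Its nearest neighbour is compound 2, with a number 2.5 percentage points higher from compound 2 to compound 3 (within the scatter), while compound 1 lies clearly higher, as a number 18 percentage points lower from compound 1 to compound 3 (beyond the scatter) shows. Compound 4 `COc1cc(NC(=O)Nc2cc(Nc3ccc(C(C)(C)C)cc3)ncn2)cc(OC)c1` differs from compound 3 only there: 4-(tert-butyl)phenyl in place of 3-chloro-4-fluorophenyl on a nitrogen on an aromatic ring. Every measured step is a swap of this same aryl group: a number 20.5 percentage points lower from compound 1 to compound 2 (beyond the scatter) and a number 18 percentage points lower from compound 1 to compound 3 (beyond the scatter) were modest drops, whereas a number 2.5 percentage points higher from compound 2 to compound 3 (within the scatter) stayed within the scatter. Two of three aryl groups thus gave much the same number, so compound 4 is expected to land near compound 3, with a number 0.5 percentage points lower from compound 3 to compound 4 (within the scatter). The estimate for compound 4 is 25%, between 12% and 40%.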

Compound 4, a percentage reported as inhibition, at one concentration (the size of the read-out at that concentration, not a potency): 17.5%
For compound 4 the middle estimate is 7.5 percentage points above the measured one; low and high end bracket the measured number.
By their numbers in this assay, from the lowest: compounds 4, 2 and 3 (each within the scatter of the next); then compound 1.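

In this assay, 4-(tert-butyl)phenyl on this nitrogen, a bulkier-named swap with no halogen, stays level with two other aryl groups, giving a number 8 percentage points lower from compound 3 to compound 4 (within the scatter) and a number 5.5 percentage points lower from compound 2 to compound 4 (within the scatter) as the steps to it. Only 5-bromo-2-methoxyphenyl stands apart, with a number 26 percentage points lower from compound 1 to compound 4 (beyond the scatter) as the widest step yet at this position, so three of the four aryl groups are not told apart here. Nothing available bears on what sets compound 1 apart. As far as these compounds go, whether 2-methoxyphenyl alone, or an aryl group carrying an amine or a carboxylic acid, would reach the number of compound 1 stays open.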